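The source may hold more compounds than are shown below. What is called first, only, known or untested is meant among the compounds shown, and "the series" means these compounds.

Compound 2 `CCC(C(=O)N1CCN(c2cccc(C)c2)CC1)N1C(=O)CCC1=O` gives the higher of the two numbers measured in a functional assay on the whole organism (strain Swiss) with Mus musculus as the target, in the maximal electroshock model, with a stated time of 0.5 h, at a dose of 300 mg/kg by the intraperitoneal route (a higher number here means a stronger effect of the compound at the dose given, a lower number a weaker effect), reaching 100%. Compound 1 `CC(C(=O)N1CCN(c2ccccc2)CC1)N1C(=O)CCC1=O` differs from compound 2 in two places; in this assay compound 1 gives 50%, a gap beyond the usual scatter. Compound 3 `CCC(C(=O)N1CCN(c2ccccc2)CC1)N1C(=O)CCC1=O` has not yet been measured; relative to compound 2 it carries hydrogen in place of methyl on an aromatic carbon. Among the compounds with values here, no step between measured compounds isolates that single change, so its effect alone is unknown. The step expected from compound 2 to compound 3, a number 25 percentage points lower from compound 2 to compound 3 (beyond the scatter), is a moderate loss. Compound 3 is therefore expected to give 75%, with a range from 40% to 100%.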

Compound 3, a percentage reported as activity, at one dose (the size of the read-out at that dose, not a potency): 75%
The estimate for compound 3 equals the measured number at the digits printed; low and high end bracket the measured number.
By their numbers in this assay, from the lowest: compound 1; then compound 3; then compound 2.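

Compound 3 gives each of the two differences between compound 1 and compound 2 a size of its own. In this assay, hydrogen in place of methyl on the aromatic carbon gives a number 25 percentage points lower from compound 2 to compound 3 (beyond the scatter), while methyl in place of hydrogen on the saturated chain carbon gives a number 25 percentage points higher from compound 1 to compound 3 (beyond the scatter). No measurement here explains why either change matters. Going by these compounds, whether a methoxy group at the aromatic position, or a longer chain at the saturated carbon, would raise or lower the effect remains open. Potency also remains open, as a single dose shows only the size of the effect.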